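A Third Methoxy Group on an Already Strongly Cytotoxic Compound

The source may hold more compounds than are shown below. What is called first, only, known or untested is meant among the compounds shown, and "the series" means these compounds.

Compound 3 `COc1ccc(-c2cc(/C=C/C(=O)c3ccc(N)cc3)[nH]n2)cc1OC` and compound 1 `COc1cc(-c2cc(/C=C/C(=O)c3ccc(N)cc3)[nH]n2)cc(OC)c1OC` differ in one place: methoxy in place of hydrogen on an aromatic carbon. In a functional assay on PC-3 cells (Homo sapiens) for cytotoxicity, read by sulforhodamine B assay, with a stated time of 48 h, tested at 10 uM (on this read-out lower numbers stand for a stronger effect and higher numbers for a weaker effect at the one concentration tested), compound 3 gives 20%, whereas compound 1 gives 1%, a step of a number 19 percentage points lower from compound 3 to compound 1 (beyond the scatter). Compound 2 `COc1ccc(C(=O)/C=C/c2cc(-c3cc(OC)c(OC)c(OC)c3)n[nH]2)cc1OC` replaces the group on the carbonyl carbon; compound 2 gives -88%, the lowest of the three, and the step is a number 89 percentage points lower from compound 1 to compound 2 (beyond the scatter). The difference between the cores of compound 2 and compound 3 is not broken down here. Compound 4 `COc1cc(C(=O)/C=C/c2cc(-c3cc(OC)c(OC)c(OC)c3)n[nH]2)cc(OC)c1OC` has not yet been measured; it differs from compound 2 by methoxy in place of hydrogen on an aromatic carbon, the same change as from compound 3 to compound 1. A smaller step is expected, a number 4 percentage points lower from compound 2 to compound 4 (within the scatter), because compound 2 already stands at -88%, leaving little room for a further drop. Compound 4 is therefore estimated at -92%, expected between -100% and -75%.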

Compound 4, a percentage reported as activity, at one concentration (the size of the read-out at that concentration, not a potency): -69%
The estimate for compound 4 lay 23 percentage points below the measured number; measured number above the stated range.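

In this assay, adding the methoxy group gives a number 19 percentage points higher from compound 2 to compound 4 (beyond the scatter), so the same change moves the number in opposite directions on the two cores: the same change on two cores in this assay, a number 19 percentage points lower (beyond the scatter) from compound 3 to compound 1 and a number 19 percentage points higher (beyond the scatter) from compound 2 to compound 4, 38 percentage points apart, beyond the scatter of two such steps

A gain in effect from this methoxy group on one core therefore did not carry over to the other, and the core has to be considered when reading this change. These two pairs do not show why the steps differ, and they are too few to support a rule for other cores in the series.

The compounds shown leave open whether an ethoxy group or a hydroxyl group at the same place would follow the methoxy group on either core.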